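The source may hold more compounds than are shown below. What is called first, only, known or untested is meant among the compounds shown, and "the series" means these compounds.

Compound 1 `C=CCSc1nc2cc(Cl)c(Cl)cc2n1C1O[C@H](CO)[C@@H](O)[C@H]1O` gives 68000 nM in a functional assay on KB cells (Homo sapiens) for inhibition; on this read-out higher numbers stand for weaker inhibition and lower numbers for stronger inhibition. Compound 2 `COc1ccc(CSc2nc3cc(Cl)c(Cl)cc3n2C2O[C@H](CO)[C@@H](O)[C@H]2O)cc1` gives 41000 nM in this assay, and compound 3 `Cc1cccc(CSc2nc3cc(Cl)c(Cl)cc3n2C2O[C@H](CO)[C@@H](O)[C@H]2O)c1` gives 30000 nM. Compound 3 holds the lowest number of the three; its gap to compound 2 lies within the scatter, while a 2.3-fold lower number from compound 1 to compound 3 (0.36 log units; beyond the scatter) lies beyond it. Compound 4 `O=[N+]([O-])c1ccc(CSc2nc3cc(Cl)c(Cl)cc3n2C2O[C@H](CO)[C@@H](O)[C@H]2O)cc1` differs from compound 3 by 4-nitrophenyl in place of 3-methylphenyl on a saturated chain carbon bound to a sulfur. For the measured compounds named here, the steps that bear on this change sit on the same saturated chain carbon bound to a sulfur: a 2.3-fold lower number from compound 1 to compound 3 (0.36 log units; beyond the scatter), a 1.7-fold lower number from compound 1 to compound 2 (0.22 log units; within the scatter) and a 1.4-fold lower number from compound 2 to compound 3 (0.14 log units; within the scatter). Exchanging one phenyl bearing a small substituent for another, as seen from compound 2 to compound 3, moved the number by less than the scatter; only the replacement of vinyl went beyond it. A step of no more than the scatter, in either direction, is therefore expected for compound 4 in this assay, as a 1.2-fold higher number from compound 3 to compound 4 (0.07 log units; within the scatter). Compound 4 is estimated at 35000 nM, with a range from 15000 nM to 80000 nM.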

Compound 4, half-maximal inhibitory concentration: 30000 nM
Beside the measured number, compound 4's estimate is 1.2-fold (0.07 log units) above it, within the range that was stated.
By their numbers in this assay, from the lowest: compounds 3, 4, 2 and 1 (each within the scatter of the next, the first and the last beyond it).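

In this assay the 4-nitrophenyl group, with its two hydrogen-bond acceptors where 3-methylphenyl has none, leaves the number within the scatter: no change at the digits printed from compound 3 to compound 4 (within the scatter) and a 1.4-fold lower number from compound 2 to compound 4 (0.14 log units; within the scatter) show compounds 2, 3 and 4 as one level at this saturated chain carbon bound to a sulfur. Against the vinyl group of compound 1 the picture is split, since a 2.3-fold lower number from compound 1 to compound 4 (0.36 log units; beyond the scatter) lies beyond the scatter, as the step to compound 3 does, while the step to compound 2 does not. No supporting measurement bears on this flat result.

Open, as far as these compounds go, is whether an amine or a carboxylic acid on the phenyl ring would move the number beyond the scatter. A longer chain in place of the benzyl group also remains untested in the compounds shown.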